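Swapping nitro for bromo at the assay limit

A few compounds are considered here, and "the series" means these few. Any claim that something is new, unique, unknown or untested is made for them only; others in the source may bear on it.

- Compound 1 `NS(=O)(=O)c1ccc(/N=C2\NC(=O)/C(=C3/C(=O)Nc4ccc([N+](=O)[O-])cc43)S2)cc1`: > 200000 nM (a limit)
- Compound 2 `NS(=O)(=O)c1cccc(/N=C2\NC(=O)/C(=C3/C(=O)Nc4ccc([N+](=O)[O-])cc43)S2)c1`: > 200000 nM (a limit)

In a functional assay on MCF7 cells (Homo sapiens) for antiproliferative activity, read by MTT assay (a lower number here means a stronger inhibitor, a higher number a weaker inhibitor), compound 2 stands at > 200000 nM, which is a limit and not a number. The same holds for both measured compounds: the limit of > 200000 nM in this assay, at which 2 of the 2 values shown sit. For the measured compounds named here, the only measured step is a step that the two limits leave unreadable from compound 1 to compound 2, so it offers no size to carry over.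

Compound 3 `NS(=O)(=O)c1cccc(/N=C2\NC(=O)/C(=C3/C(=O)Nc4ccc(Br)cc43)S2)c1` carries bromo in place of nitro on an aromatic carbon. Going by the values given here, no measured pair shows this change, so the data give neither its size nor its direction. The expectation rests on compound 1 and compound 2 sharing one limit, (the limit of > 200000 nM in this assay, at which 2 of the 2 values shown sit), and a reported limit is the likeliest result again.

The expected change is a number no higher from compound 2 to compound 3 (the limit leaves the size open). Compound 3 is estimated at 200000 nM, with an expected range from 50000 nM to 400000 nM.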

Compound 3, half-maximal inhibitory concentration: > 200000 nM
Compound 3: only a limit was reported; the forecaster's own chance of this, stated with the estimate: 65%; the middle value sits exactly at the limit.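

No size can be read for the step between compound 2 and compound 3, and compound 3 shares one reported limit with compound 1 and compound 2: the limit of > 200000 nM in this assay, at which 3 of the 3 values shown sit.

The compounds shown leave open whether either change, bromo for nitro or 3-sulfamoylphenyl for 4-sulfamoylphenyl, has any effect.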